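The compounds below may be only part of what the source reports. "The series", "measured", "known", "first", "only" and "open" are said of these compounds alone.

Compound 1 `COc1ccc2c(c1)C(CCN1CCN(c3cccc4c3OCCO4)CC1)C2` and compound 2 `c1ccc2c(c1)CCCC2CCN1CCN(c2cccc3c2OCCO3)CC1` were both tested in a functional assay on the whole organism for antagonist activity, with Rattus norvegicus as the target; a higher number here means that more compound is needed for the effect, a lower number that less compound is needed. Compound 1 gives 0.63 mg/kg, the highest of the two numbers measured here, so it needs the most compound for the effect. Compound 2 gives 0.16 mg/kg, a lower number that lies beyond the usual scatter of this assay.

Compound 3 `COc1cc2c(cc1OC)C(CCN1CCN(c3cccc4c3OCCO4)CC1)C2` has not yet been measured. It differs from compound 1 in one place: methoxy in place of hydrogen on an aromatic carbon. Among the measured compounds shown here, nothing among the measured compounds shows how this particular change affects the read-out, so no step of this kind is known.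

For the measured compounds named here, with only the pair of compounds 1 and 2 to go by, the expected step of no change at the digits printed from compound 1 to compound 3 (within the scatter) is small and within the usual scatter, with no direction favoured. Compound 3 is therefore estimated at 0.63 mg/kg, in a range from 0.2 mg/kg to 2 mg/kg.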

Compound 3, minimum effective dose: 1.25 mg/kg
Estimate against measurement, compound 3: 2.0-fold (0.30 log units) below, and the stated range covers the measured number.
By their numbers in this assay, from the lowest: compound 2; then compounds 1 and 3 (each within the scatter of the next).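

The step of a 2.0-fold higher number from compound 1 to compound 3 (0.30 log units; within the scatter) in this assay comes with methoxy in place of hydrogen on an aromatic carbon, ortho to the methoxy group that compound 1 already carries. Among the compounds shown here, this is the first reading for this position: with a second methoxy there, the result stays within the usual scatter, so the measurement cannot separate the two compounds. It rests on a single pair of compounds, and nothing measured here explains the result.

Going by these compounds, it remains open whether a different group at this position, such as a hydroxyl, a chlorine atom or the longer ethoxy, would give a step beyond the scatter. On these data alone, it is also open whether this position would respond in the same way if the core of compound 1 were changed elsewhere.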